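A few compounds are considered here, and "the series" means these few. Any claim that something is new, unique, unknown or untested is made for them only; others in the source may bear on it.

In a functional assay on HL-60 cells (Homo sapiens) for cytotoxicity, read by WST assay, with a stated time of 48 h (on this read-out higher numbers stand for an effect only at larger amounts of compound and lower numbers for an effect already at smaller amounts), the measured compounds read as follows:

- compound 1 `COc1ccc(C[C@H]2C(=O)OC[C@@H]2Cc2ccccc2)cc1` gives 67000 nM
- compound 2 `CCCCOc1ccc(C[C@H]2C(=O)OC[C@@H]2Cc2ccccc2)cc1` gives 23000 nM
- compound 3 `O=C1OC[C@H](Cc2ccccc2)[C@H]1Cc1ccc(Cl)cc1` gives 36000 nM

Compound 1 sits at the top end of these three numbers, where a 1.9-fold lower number from compound 1 to compound 3 (0.27 log units; within the scatter) stays within the scatter and a 2.9-fold lower number from compound 1 to compound 2 (0.46 log units; beyond the scatter) lies beyond it.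

The next compound to be measured is compound 4 `COc1ccc(C[C@H]2C(=O)OC[C@@H]2Cc2ccccc2)cc1OC`. It departs from compound 1 by methoxy in place of hydrogen on an aromatic carbon, which is methoxy in place of hydrogen on an aromatic carbon, ortho to a methoxy group and meta to a large group. For the measured compounds named here, no measured step makes this exact change, so the evidence is indirect. The two nearest steps alter the substituent already on that ring: a 2.9-fold lower number from compound 1 to compound 2 (0.46 log units; beyond the scatter) is modest, and a 1.9-fold lower number from compound 1 to compound 3 (0.27 log units; within the scatter) does not leave the scatter. Neither moves the number far, so in this assay no step beyond the scatter is expected here, with a slight drift towards a lower number as the likelier direction. The expected step is a 1.3-fold lower number from compound 1 to compound 4 (0.13 log units; within the scatter) and would stay within the scatter. For compound 4 the estimated value is 50000 nM, with an expected range from 22000 nM to 110000 nM as the likely outcome.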

Compound 4, half-maximal effective concentration: > 100000 nM
Compound 4: only a limit was reported (the forecaster's own chance of this, stated with the estimate: 10%); at least 2.0-fold (0.30 log units) between middle value and limit.
By their numbers in this assay, from the lowest: compounds 2, 3 and 1 (each within the scatter of the next, the first and the last beyond it). At a limit, above all of these: compound 4.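

Methoxy in place of hydrogen on an aromatic carbon, ortho to a methoxy group and meta to a large group, is the first change here that adds a group to the ring instead of altering the one already there, and in this assay it brings an at least 1.4-fold higher number from compound 1 to compound 4 (0.17 log units; that floor lies within the scatter). Compound 4 gives > 100000 nM in this assay, which is a limit and not a number, so only a floor for the step can be read: the limit of > 100000 nM in this assay, at which 1 of the 4 values shown sits. Lengthening the chain on the existing oxygen brought a 2.9-fold lower number from compound 1 to compound 2 (0.46 log units; beyond the scatter), whereas the added methoxy shows no such fall, although its floor alone does not leave the scatter.

Going by these compounds, it stays open whether a hydroxyl, a fluoro or an amine on this same carbon would read as the added methoxy does, or whether the effect belongs to methoxy alone. Also open, on these data alone, is whether a longer chain such as butoxy at this carbon would bring the number down, as it did on the existing oxygen.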